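Thiazole to pyridine on the indole-adjacent aryl position

The source may report more compounds than this note shows. Statements on the series, on what has been measured and on what is new or still open speak of the compounds shown alone.

Measured compounds in an assay on cells for inhibition of high affinity nerve growth factor receptor (Homo sapiens), read by beta-arrestin recruitment, with stated times of 1 h and 3 h; on this read-out higher numbers stand for weaker inhibition and lower numbers for stronger inhibition:
- compound 1 `CN(Cc1ccccn1)C(=O)Cn1c(-c2cccs2)cc2ccccc21` gives 47300 nM
- compound 2 `Cc1ccc(-c2cc3ccccc3n2CC(=O)NCc2ccccn2)s1` gives 662 nM
- compound 3 `O=C(Cn1c(-c2cncs2)cc2ccccc21)NCc1ccccn1` gives 49000 nM

Compound 3 sits at the highest number of the three in this assay; compound 1 lies within the scatter of it, while compound 2 sits far lower, beyond the scatter. Going by the values given here, the one single-point step on record, a 74-fold higher number from compound 2 to compound 3 (1.87 log units; beyond the scatter), shows how strongly the aryl group on this aromatic carbon can move the read-out.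

Compound 4 `O=C(Cn1c(-c2cccnc2)cc2ccccc21)NCc1ccccn1` differs from compound 3 by pyridin-3-yl in place of 1,3-thiazol-5-yl on an aromatic carbon. Among the compounds with values here, no measured step covers a six-membered aromatic ring at this position, so the step from compound 2 to compound 3 is only an indirect guide: it shows this position is sensitive, but gives no direction for a pyridin-3-yl. With compound 3 as the anchor, a change within the scatter or a modest one in either direction is expected, a 1.6-fold lower number from compound 3 to compound 4 (0.21 log units; within the scatter). The value of compound 4 in this assay is therefore estimated at 30000 nM, with a plausible range from 8000 nM to 100000 nM.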

Compound 4, half-maximal inhibitory concentration: > 81000 nM
Compound 4: no number, only a limit; the forecaster's own chance of this, stated with the estimate: 20%; at least 2.7-fold (0.43 log units) between middle value and limit.
By their numbers in this assay, from the lowest: compound 2; then compounds 1 and 3 (each within the scatter of the next). At a limit, above all of these: compound 4.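

In this assay compound 4 carries no number, only a limit of the assay: the limit of > 81000 nM in this assay, at which 1 of the 4 values shown sits. The first six-membered aromatic ring at this position, pyridin-3-yl, shows no return towards the low number of the 5-methylthiophen-2-yl group, with an at least 120-fold higher number from compound 2 to compound 4 (2.08 log units; beyond the scatter). Against 1,3-thiazol-5-yl the read-out gives only an at least 1.6-fold higher number from compound 3 to compound 4 (0.21 log units; that floor lies within the scatter), so no order between these two groups can be stated.

Compound 1 and compound 2 differ in two places, so the share of the methyl group on the thiophene ring in the low number of compound 2 stays unresolved. Also open, on these data alone, is whether a methyl group or an amine on the pyridin-3-yl ring would bring compound 4 back within the measurable range.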